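The compounds below may be only part of what the source reports. "The series", "measured", "known", "first", "only" and "open" are said of these compounds alone.

Measured so far in an assay on isolated protein for antagonist activity at Bile acid receptor (Homo sapiens), read by TR-FRET, with a stated time of 20 min; on this read-out higher numbers stand for weaker inhibition and lower numbers for stronger inhibition:
compound 1 `Cc1ccc(-c2nn(C(C)C)cc2C(=O)Nc2ccc(C)c(S(=O)(=O)N3CCOCC3)c2)cc1`, 49.1 nM
compound 2 `Cc1ccc(-c2nn(CC3CC3)cc2C(=O)Nc2ccc(C)c(S(=O)(=O)N3CCOCC3)c2)cc1`, 76.9 nM

On the numbers shown, compound 2 and compound 1 lie within the scatter of each other: a 1.6-fold higher number from compound 1 to compound 2 (0.19 log units; within the scatter). Compound 3 `Cc1ccc(-c2nn(-c3ccccc3)cc2C(=O)Nc2ccc(C)c(S(=O)(=O)N3CCOCC3)c2)cc1` has not been measured. It keeps the shared core and differs from compound 2 in one place: phenyl in place of cyclopropylmethyl on an aromatic nitrogen. For the measured compounds named here, the only measured step that bears on this change is the one at the same aromatic nitrogen, and that step stayed within the scatter. The two numbers give no sign that an exchange at this nitrogen moves this assay strongly, so no step beyond the scatter is expected for compound 3 in either direction, a 1.1-fold higher number from compound 2 to compound 3 (0.04 log units; within the scatter). The estimate for compound 3 in this assay is accordingly 85 nM, with an expected range from 30 nM to 250 nM.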

Compound 3, half-maximal inhibitory concentration: 47 nM
The estimate for compound 3 lay 1.8-fold (0.26 log units) above the measured number; low and high end bracket the measured number.
By their numbers in this assay, from the lowest: compounds 3, 1 and 2 (each within the scatter of the next).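

At the aromatic nitrogen, the series now includes an aromatic ring as well as non-aromatic groups: in this assay, phenyl in place of cyclopropylmethyl gives a 1.6-fold lower number from compound 2 to compound 3 (0.21 log units; within the scatter) and phenyl in place of isopropyl gives a 1.0-fold lower number from compound 1 to compound 3 (0.02 log units; within the scatter). Phenyl, a six-membered aromatic ring of carbon only, is therefore accepted at this position with no step beyond the scatter from either non-aromatic group, and the three groups cannot be told apart here. No measurement at hand explains this flat response.

Phenyl and cyclopropylmethyl both lack hydrogen-bond donors, acceptors and net charge, so it remains open whether an amine or a carboxylic acid at this nitrogen would step beyond the scatter. Going by these compounds, a longer chain or a methoxy group on the phenyl ring also remains open.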